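The source may report more compounds than this note shows. Statements on the series, on what has been measured and on what is new or still open speak of the compounds shown alone.

Of the compounds shown here, three that share one core have been tested in an assay on HeLa cells for displacement of a labelled ligand from adenosine receptor A3 (Homo sapiens), read by fluorescence polarization, with a stated time of 30 min; a lower number here means a stronger inhibitor, a higher number a weaker inhibitor. Compound 1 `COc1ccc(-c2cc(NC(=O)CCC(=O)NCC(=O)NC3CCCCC3)nc(-c3ccc(OC)cc3)n2)cc1` gives 74200 nM. Compound 2 `COc1ccc(-c2cc(NC(=O)CCC(=O)NCC(=O)NCc3ccccc3)nc(-c3ccc(OC)cc3)n2)cc1` carries benzyl in place of cyclohexyl on an amide-type nitrogen and gives 50800 nM; this change produced a 1.5-fold lower number from compound 1 to compound 2 (0.16 log units; within the scatter). Compound 3 `COc1ccc(-c2cc(NC(=O)CCC(=O)N3CCN(CC(=O)NC4CCCCC4)CC3)nc(-c3ccc(OC)cc3)n2)cc1` gives 35100 nM in this assay, the lowest of the three numbers, although the difference between its core and the core of compound 1 is not broken down here. Compound 4 `COc1ccc(-c2cc(NC(=O)CCC(=O)N3CCN(CC(=O)NCc4ccccc4)CC3)nc(-c3ccc(OC)cc3)n2)cc1` has not yet been measured. It differs from compound 3 by benzyl in place of cyclohexyl on an amide-type nitrogen, the same kind of change seen between compound 1 and compound 2, at a place described in the same words. Because the earlier step was a 1.5-fold lower number from compound 1 to compound 2 (0.16 log units; within the scatter), a step of similar small size is expected now. Compound 4 is therefore estimated to give 25000 nM, most likely between 10000 nM and 60000 nM. The expected step is a 1.4-fold lower number from compound 3 to compound 4 (0.15 log units; within the scatter).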

Compound 4, inhibition constant: 11600 nM
Beside the measured number, compound 4's estimate is 2.2-fold (0.33 log units) above it; measured number inside the range.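

In this assay, benzyl in place of cyclohexyl on the amide-type nitrogen gives a 3.0-fold lower number from compound 3 to compound 4 (0.48 log units; beyond the scatter). Set beside the earlier step, this result does not separate the two cores: the same change on two cores in this assay, a 1.5-fold lower number (0.16 log units; within the scatter) from compound 1 to compound 2 and a 3.0-fold lower number (0.48 log units; beyond the scatter) from compound 3 to compound 4, 2.1-fold (0.32 log units) apart, within the scatter of two such steps. The change therefore carries from one core to the other without a measurable difference in step size, but two pairs cannot show that the step has the same size on both cores, or predict its size on a further core.

The compounds shown hold only cyclohexyl and benzyl at this place. From the compounds shown here alone, how phenyl or phenethyl would read there on either core remains open, as does a benzyl ring bearing a carboxylic acid or an amine.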